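A few compounds are considered here, and "the series" means these few. Any claim that something is new, unique, unknown or untested is made for them only; others in the source may bear on it.

Measured so far in a functional assay on A549 cells (Homo sapiens) for antiproliferative activity, read by sulforhodamine B assay, with a stated time of 48 h; a lower number here means a stronger inhibitor, a higher number a weaker inhibitor:

compound 1 `COc1cc(OC)c(C=C(C(=O)/C=C/c2cccc(OC)c2OC)C(=O)/C=C/c2cccc(OC)c2OC)c(OC)c1` gives 630 nM
compound 2 `COc1cc(C=C(C(=O)/C=C/c2cccc(OC)c2OC)C(=O)/C=C/c2cccc(OC)c2OC)cc(OC)c1O` gives 240 nM

Compound 2, at 240 nM, holds the lower of the two numbers. Among the compounds with values here, the one measured step leads to it, a 2.6-fold lower number from compound 1 to compound 2 (0.42 log units; beyond the scatter), and it brought 4-hydroxy-3,5-dimethoxyphenyl in place of 2,4,6-trimethoxyphenyl on a double-bonded chain carbon bound to a double-bonded chain carbon.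

Compound 3 `COc1cccc(/C=C/C(=O)C(=Cc2ccc(OC)c(OC)c2OC)C(=O)/C=C/c2cccc(OC)c2OC)c1OC` changes that same place again: 2,3,4-trimethoxyphenyl in place of 4-hydroxy-3,5-dimethoxyphenyl on a double-bonded chain carbon bound to a double-bonded chain carbon. Within the data shown here, the 4-hydroxy-3,5-dimethoxyphenyl thus gives way to another trimethoxyphenyl, but not to the one carried by compound 1. Among the measured compounds shown here, the only guide is therefore a 2.6-fold lower number from compound 1 to compound 2 (0.42 log units; beyond the scatter), a modest step, read in reverse. The data do not show whether 2,3,4-trimethoxyphenyl will match 2,4,6-trimethoxyphenyl in this assay. A move to a higher number is expected, of similar size to that step or somewhat smaller. The estimated step is a 2.1-fold higher number from compound 2 to compound 3 (0.32 log units; beyond the scatter). For compound 3 the expected value is 500 nM, with an estimated range from 200 nM to 1200 nM.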

Compound 3, half-maximal inhibitory concentration: 260 nM
Compound 3: the middle estimate sits 1.9-fold (0.28 log units) above what was measured; the measured number falls inside the stated range.
By their numbers in this assay, from the lowest: compounds 2 and 3 (each within the scatter of the next); then compound 1.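

In this assay, the step at this place that removes the one hydrogen-bond donor of 4-hydroxy-3,5-dimethoxyphenyl is a 1.1-fold higher number from compound 2 to compound 3 (0.03 log units; within the scatter), so among these compounds that donor makes no difference that can be read, and a ring without it sits level with the hydroxy-bearing one. The other new step is a 2.4-fold lower number from compound 1 to compound 3 (0.38 log units; beyond the scatter), and it joins two trimethoxyphenyl groups, which shows that on a double-bonded chain carbon bound to a double-bonded chain carbon the arrangement of the three methoxy groups can shift the number beyond the scatter, even though their count stays the same; 2,4,6-trimethoxyphenyl is the group that stands apart from the other two. Nothing at hand gives a measured reason for either result.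

What the three compounds leave open is how far this place tolerates a ring of a different kind, such as one carrying an amine, a fluorine or a carboxylic acid, since all three rings shown bear only methoxy or hydroxy groups. They also leave open whether the same ranking would hold if the remainder of the shared core were altered, because that remainder is identical in all three.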